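The source may hold more compounds than are shown below. What is called first, only, known or untested is meant among the compounds shown, and "the series" means these compounds.

Measured so far in an ADME assay on Huh-7 cells (Homo sapiens) for cytotoxicity, read by MTT assay, with a stated time of 72 h; a higher number here means that more compound is tolerated, a lower number that less compound is tolerated:

Compound 1 `Cc1cc(=O)oc2cc(OCc3cn(-c4ccc(OC(F)(F)F)cc4)nn3)ccc12`: > 100 ug/mL, which is a limit of the assay rather than a number.

Compound 2 `Cc1cc(=O)oc2cc(OCc3cn(-c4cccc(F)c4)nn3)ccc12`: > 100 ug/mL, again a limit of the assay rather than a number.

Compound 2 therefore has no exact reading in this assay. All that can be said is that compound 2 sits at the limit of > 100 ug/mL in this assay, at which 2 of the 2 values shown sit, so both values shown end at the same limit, and neither can be placed above or below the other.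

Compound 3 `Cc1cc(=O)oc2cc(OCc3c[nH]nn3)ccc12` is the next compound to be tested in this assay. The change from compound 2 is hydrogen in place of 3-fluorophenyl on an aromatic nitrogen, in words: hydrogen in place of 3-fluorophenyl on an aromatic nitrogen. Among the measured compounds shown here, no step between two measured compounds is available to say how much such a change moves the reading in this assay. Since both readings so far sit at the same limit, the step is expected to stay within the scatter, as a step that the limit leaves unreadable from compound 2 to compound 3. Compound 3 is thus expected to give about 150 ug/mL, somewhere between 60 ug/mL and 400 ug/mL, most likely reported again as a limit.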

Compound 3, half-maximal cytotoxic concentration: > 100 ug/mL
Compound 3 ended at the assay's limit; the forecaster's own chance of this, stated with the estimate: 80%; the middle value is on the limit's open side.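

No step can be read from compound 2 to compound 3, because both readings are limits of the assay rather than numbers: the limit of > 100 ug/mL in this assay, at which 3 of the 3 values shown sit.

The compounds shown leave open how much of each compound is actually tolerated, and whether hydrogen in place of 3-fluorophenyl on an aromatic nitrogen changes the reading at all.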